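Furan-2-yl in Place of Cyclopropyl: An Expected Step

A few compounds are considered here, and "the series" means these few. Any claim that something is new, unique, unknown or untested is made for them only; others in the source may bear on it.

Of the compounds shown here, three have been measured in a functional assay on the whole organism (plasma, strain Sprague-Dawley) with Rattus norvegicus as the target, with a stated time of 2 h, at a dose of 25 mg/kg by the oral route; a higher number here means a stronger effect of the compound at the dose given, a lower number a weaker effect. Compound 1 `c1ccc(C(/N=C2\CCCCCN2)C2CC2)cc1` gives 18%. Compound 2 `c1ccc(C(/N=C2\CCCCCCN2)C2CC2)cc1` shares much of its build with compound 1, but the difference between the two cores is not broken down here; in this assay compound 2 gives 26%, which lies within the scatter of compound 1. Compound 3 `c1ccc(C(/N=C2\CCCCCN2)c2ccco2)cc1` differs from compound 1 in one place, (furan-2-yl in place of cyclopropyl on a saturated chain carbon bound to an aromatic carbon and a double-bonded nitrogen), and in this assay compound 3 gives 34%. That single change made a number 16 percentage points higher from compound 1 to compound 3 (beyond the scatter).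

Compound 4 `c1ccc(C(/N=C2\CCCCCCN2)c2ccco2)cc1` has not yet been measured. It differs from compound 2 by the same change, (furan-2-yl in place of cyclopropyl on a saturated chain carbon bound to an aromatic carbon and a double-bonded nitrogen), made on the core of compound 2 instead. This change has so far been seen only once among these compounds, so the expectation for compound 4 rests on a single example. For compound 4 a step of a number 16 percentage points higher from compound 2 to compound 4 (beyond the scatter) is expected, beside the earlier one, because a number 16 percentage points higher from compound 1 to compound 3 (beyond the scatter) is the only comparable case. Compound 4 is therefore estimated to give 42% in this assay, with a likely range from 28% to 56%.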

Compound 4, a percentage reported as inhibition, in the whole organism at one dose (the size of the read-out at that dose, not a potency): 29%
Compound 4: middle estimate off by 13 percentage points, on the high side, within the range that was stated.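

In this assay, the same swap of furan-2-yl for cyclopropyl on the core of compound 2 gave a number 3 percentage points higher from compound 2 to compound 4 (within the scatter), so on this core alone its effect cannot be told apart from the ordinary spread of the measurements. Set side by side, the two steps look different in size, yet the gap between them is no larger than two such steps could show by chance: the same change on two cores in this assay, a number 16 percentage points higher (beyond the scatter) from compound 1 to compound 3 and a number 3 percentage points higher (within the scatter) from compound 2 to compound 4, 13 percentage points apart, within the scatter of two such steps This means the result does not show that the core changes what the swap does, and it does not show that the swap carries over with the same size either, as a single pair on each core cannot settle the question in either direction.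

The compounds shown leave open what a carboxylic acid or a longer chain would do in the same place, on either core. They also leave open how these compounds would compare at other doses, as each number gives the size of the effect at one dose and not a potency.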